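Methoxy on the aniline ring: an unmeasured step from compound 1

The source may report more compounds than this note shows. Statements on the series, on what has been measured and on what is new or still open speak of the compounds shown alone.

The shared core carries an aniline-type ring, and the three measured compounds differ only in what that ring bears. In a functional assay on HepG2 cells (Homo sapiens) for inhibition, read by MTT assay, with a stated time of 72 h (on this read-out higher numbers stand for weaker inhibition and lower numbers for stronger inhibition), compound 1 `C#CCSc1nc(Nc2ccccc2)c2ccncc2n1` gives 29400 nM, which is the second highest of the three numbers. Compound 2 `C#CCSc1nc(Nc2ccc(F)cc2)c2ccncc2n1` gives 10800 nM in this assay, and compound 3 `C#CCSc1nc(Nc2ccc(Br)cc2)c2ccncc2n1` gives 56200 nM. The step from compound 1 to compound 2, fluoro in place of hydrogen on an aromatic carbon, was a 2.7-fold lower number from compound 1 to compound 2 (0.43 log units; beyond the scatter); the step from compound 1 to compound 3, bromo in place of hydrogen on an aromatic carbon, was a 1.9-fold higher number from compound 1 to compound 3 (0.28 log units; within the scatter).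

Compound 4 `C#CCSc1nc(Nc2ccccc2OC)c2ccncc2n1` differs from compound 1 by methoxy in place of hydrogen on an aromatic carbon. Neither measured step covers a methoxy group or a position ortho to a large group, so both only show that a single substituent on this ring shifts the number modestly in either direction. Compound 4 is therefore expected to sit near compound 1, with an estimated step of a 1.2-fold lower number from compound 1 to compound 4 (0.07 log units; within the scatter). The estimated value for compound 4 is 25000 nM, within a range from 8000 nM to 80000 nM.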

Compound 4, half-maximal inhibitory concentration: 4530 nM
Compound 4: middle estimate off by 5.5-fold (0.74 log units), on the high side, and the stated range ends above it.
By their numbers in this assay, from the lowest: compound 4; then compound 2; then compounds 1 and 3 (each within the scatter of the next).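

In this assay, methoxy in place of hydrogen on an aromatic carbon, ortho to a large group, gave a 6.5-fold lower number from compound 1 to compound 4 (0.81 log units; beyond the scatter) and so moved the number beyond the scatter. This step runs the same way as a 2.7-fold lower number from compound 1 to compound 2 (0.43 log units; beyond the scatter) and shows that lower numbers on this ring are not confined to fluoro, whereas a 1.9-fold higher number from compound 1 to compound 3 (0.28 log units; within the scatter) stays within the scatter. Compound 4 is also the only compound shown with a group ortho to a large group, and nothing given here accounts for its step.

With one such compound, the effect of methoxy cannot be separated from the effect of its place on the ring. From the compounds shown here alone, whether a hydroxyl, an amine or a longer chain such as ethoxy in the same place would move the number the same way remains open, as does the result of methoxy elsewhere on the ring.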